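A few compounds are considered here, and "the series" means these few. Any claim that something is new, unique, unknown or untested is made for them only; others in the source may bear on it.

Working notes on the series, following the step from compound 1 to compound 3.

Compound 1 `COc1cc(CN(C(=O)CSc2nc3ccccc3s2)c2cc(OC)c(OC)c(OC)c2)cc(OC)c1OC` gives > 80000 nM in a functional assay on PC-3 cells (Homo sapiens) for antiproliferative activity, read by MTT assay, with a stated time of 48 h (a higher number here means a weaker inhibitor, a lower number a stronger inhibitor), and this entry is a limit, not a number. Compound 2 `COc1ccc(CN(C(=O)CSc2nc3cc(Br)ccc3s2)c2cc(OC)c(OC)c(OC)c2)cc1O` gives a measured number in this assay of 8210 nM and is the only numerical anchor so far.

Compound 3 `COc1ccc(CN(C(=O)CSc2nc3ccccc3s2)c2cc(OC)c(OC)c(OC)c2)cc1N` is still unmeasured. It departs from compound 1 by 3-amino-4-methoxyphenyl in place of 3,4,5-trimethoxyphenyl on a saturated chain carbon bound to an amide-type nitrogen and so carries 3-amino-4-methoxyphenyl in place of 3,4,5-trimethoxyphenyl on a saturated chain carbon bound to an amide-type nitrogen.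

Going by the values given here, no measured step covers this change, so the expectation rests on little. Compound 2 at 8210 nM shows that a measured number can be reached among these compounds, and this is the only support for expecting a gain. The estimated step of an at least 16-fold lower number from compound 1 to compound 3 (1.20 log units; beyond the scatter) is expected to point toward a stronger inhibitor, with its size poorly constrained. Another reading that stops at a limit remains possible.

For compound 3 the expected value is 5000 nM within an estimated range from 300 nM to 60000 nM in this assay for now.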

Compound 3, half-maximal inhibitory concentration: 7510 nM
For compound 3 the middle estimate is 1.5-fold (0.18 log units) below the measured one; low and high end bracket the measured number.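

The change to 3-amino-4-methoxyphenyl in place of 3,4,5-trimethoxyphenyl on a saturated chain carbon bound to an amide-type nitrogen gives an at least 10-fold lower number from compound 1 to compound 3 (1.02 log units; beyond the scatter) in this assay, the first single-place step in the series, so this position is shown to govern whether the core of compound 1 gives a measurable number at all. The reading of compound 1 is a limit and not a number, so the step gives only a minimum size: the limit of > 80000 nM in this assay, at which 1 of the 3 values shown sits. The change is also not a single-atom one: the entering group has 9 heavy atoms and 1 hydrogen-bond donor, whereas the leaving group has 12 heavy atoms and 0 hydrogen-bond donors.

Going by these compounds alone, the single step does not separate the arrival of the amino group from the loss of the methoxy groups, and compound 2 differs from compound 3 in more than one place, so it cannot settle this. Going by these compounds, how a dimethylamino group or an acetamide would read in this assay in place of the amino group on this ring remains open.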